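The source may report more compounds than this note shows. Statements on the series, on what has been measured and on what is new or still open speak of the compounds shown alone.

Working notes on the series.

Of the compounds shown here, three have so far been measured in a functional assay on DU-145 cells (Homo sapiens) for inhibition, read by MTT assay, with a stated time of 72 h; on this read-out higher numbers stand for weaker inhibition and lower numbers for stronger inhibition. Compound 1 `O=C1C=C(N2CCN(c3ccc(F)cc3)CC2)C(=O)c2ccccc21` gives 11700 nM. Compound 2 `O=C1C=C(N2CCN(c3ccc(F)c(Cl)c3)CC2)C(=O)c2ccccc21` gives 32200 nM. Compound 3 `O=C1C=C(N2CCC(c3ccccc3)CC2)C(=O)c2c(O)cccc21` gives 3000 nM, the lowest of the three numbers, and its distance to compound 1 as well as to compound 2 is beyond the scatter. How the core of compound 3 differs from the core of compound 1 is not broken down here.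

Compound 2 differs from compound 1 by chloro in place of hydrogen on an aromatic carbon. The step this made is a 2.8-fold higher number from compound 1 to compound 2 (0.44 log units; beyond the scatter).

Compound 4 `O=C1C=C(N2CCC(c3ccc(Cl)cc3)CC2)C(=O)c2c(O)cccc21` is not yet measured in this assay. It differs from compound 3 by chloro in place of hydrogen on an aromatic carbon. Among the compounds shown this change occurs two times in all, so the pair compound 3 to compound 4 repeats the same kind of change as the pair compound 1 to compound 2, though not the same change: in compound 2 the entering chloro sits ortho to a fluoro group and meta to a large group, on the core of compound 1; in compound 4 it sits para to a large group, on the core of compound 3.

The expectation for compound 4 is a step of a 2.0-fold higher number from compound 3 to compound 4 (0.30 log units; within the scatter), placed beside the earlier step and resting only on that one observation a 2.8-fold higher number from compound 1 to compound 2 (0.44 log units; beyond the scatter), with the changed surroundings leaving room for a smaller or larger move. The estimate for compound 4 in this assay is 6000 nM, expected to fall between 2200 nM and 16000 nM.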

Compound 4, half-maximal inhibitory concentration: 2600 nM
Beside the measured number, compound 4's estimate is 2.3-fold (0.36 log units) above it; measured number inside the range.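

In this assay, going by these compounds alone, chloro in place of hydrogen on an aromatic carbon gives a 1.2-fold lower number from compound 3 to compound 4 (0.06 log units; within the scatter), so on the core of compound 3 the change produces no step that can be told from the scatter, and the step seen on the core of compound 1 does not carry over in size: the same change on two cores in this assay, a 2.8-fold higher number (0.44 log units; beyond the scatter) from compound 1 to compound 2 and a 1.2-fold lower number (0.06 log units; within the scatter) from compound 3 to compound 4, 3.2-fold (0.50 log units) apart, beyond the scatter of two such steps. Within the data shown here, the change therefore cannot be treated as a fixed increment across these two cores, although this rests on only two pairs and says nothing about any wider trend. It does not show that the core alone is responsible, since the two pairs also differ in the ring that takes the chloro, which carries a fluoro group only in compound 1 and compound 2, and in where the chloro enters.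

Still open, on these data alone, is whether the gap between the two steps follows the core or the fluoro group, a question that phenyl and 4-chlorophenyl on the core of compound 1 would help to separate. The compounds shown also leave open how other groups at the same place on the ring of compound 3, such as a methoxy group, an amine or a carboxylic acid, would compare with chloro.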